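Amine swap on the side chain of compound 2

The source may report more compounds than this note shows. Statements on the series, on what has been measured and on what is new or still open speak of the compounds shown alone.

The study compares three amides sharing a core, differing only in the amine at the end of a side chain. In a functional assay on MCF7 cells (Homo sapiens) for antiproliferative activity (on this read-out lower numbers stand for stronger inhibition and higher numbers for weaker inhibition), compound 1 `CC(C)=CCc1cc(C(=O)Nc2cc3ccc(OCCC4CCCCN4)c(C)c3oc2=O)ccc1O` gives 710 nM. Compound 2 `CC(C)=CCc1cc(C(=O)Nc2cc3ccc(OCCCN4CCCC4)c(C)c3oc2=O)ccc1O` gives 990 nM in this assay, and compound 3 `CC(C)=CCc1cc(C(=O)Nc2cc3ccc(OCCCNCC(C)C)c(C)c3oc2=O)ccc1O` gives 1320 nM in this assay. Compound 2 sits between the other two, since the step of a 1.4-fold higher number from compound 1 to compound 2 (0.14 log units; within the scatter) and the step of a 1.3-fold higher number from compound 2 to compound 3 (0.12 log units; within the scatter) are both within the scatter, as is the step of a 1.9-fold higher number from compound 1 to compound 3 (0.27 log units; within the scatter). On these numbers no amine stands apart from another.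

Compound 4 `CC(C)=CCc1cc(C(=O)Nc2cc3ccc(OCCCN(C)C4CCCCC4)c(C)c3oc2=O)ccc1O` carries the change (cyclohexyl(methyl)amino in place of pyrrolidin-1-yl on a saturated chain carbon, three bonds along the chain from an oxygen on an aromatic ring). The three measured steps all concern the same amine position and none moved the read-out beyond the scatter, so he expects the step of a 1.0-fold higher number from compound 2 to compound 4 (0.00 log units; within the scatter) to stay within the scatter as well, with no clear direction. For compound 4 in this assay he therefore estimates 1000 nM, with a range from 450 nM to 2200 nM.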

Compound 4, half-maximal inhibitory concentration: 1080 nM
Compound 4: the middle estimate sits 1.1-fold (0.03 log units) below what was measured; measured number inside the range.
By their numbers in this assay, from the lowest: compounds 1, 2, 4 and 3 (each within the scatter of the next).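

In this assay, putting cyclohexyl(methyl)amino in place of pyrrolidin-1-yl, with 8 heavy atoms entering for 5 and a six-membered ring of carbon only entering for a five-membered ring holding nitrogen, gives a 1.1-fold higher number from compound 2 to compound 4 (0.04 log units; within the scatter), so this position accepts a clearly bigger amine without leaving the scatter. The comparisons with the other two amines, a 1.2-fold lower number from compound 3 to compound 4 (0.09 log units; within the scatter) and a 1.5-fold higher number from compound 1 to compound 4 (0.18 log units; within the scatter), stay within the scatter as well, and none of the four amines can yet be separated from another on this read-out. Nothing measured is at hand that would explain this flat picture.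

The compounds shown leave open whether a morpholine or an amine carrying a carboxylic acid in this place would move the read-out beyond the scatter. They also leave open whether a longer chain bearing the same pyrrolidin-1-yl would do so.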